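Alkyl size on the carbamoyl nitrogen: compound 3 to compound 4

The source may hold more compounds than are shown below. What is called first, only, known or untested is meant among the compounds shown, and "the series" means these compounds.

Measured so far:
Compound 1, `CCC(=O)N1CCC(NS(=O)(=O)c2ccc(NC(=O)c3ccccc3C)c3ccccc23)CC1`: in an assay on L1.2 cells for binding affinity to C-C chemokine receptor type 8 (Homo sapiens) (a higher number here means a weaker inhibitor, a lower number a stronger inhibitor), compound 1 gives 2.5 nM.
Compound 2, `CC(=O)N1CCC(NS(=O)(=O)c2ccc(NC(=O)c3ccccc3C)c3ccccc23)CC1`: in this assay compound 2 gives 6.7 nM.
Compound 3, `CNC(=O)N1CCC(NS(=O)(=O)c2ccc(NC(=O)c3ccccc3C)c3ccccc23)CC1`: in this assay compound 3 gives 0.7 nM.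

Compound 3 holds the lowest number of the three; its nearest neighbour is compound 1, with a 3.6-fold lower number from compound 1 to compound 3 (0.55 log units; beyond the scatter), and the widest gap is to compound 2, with a 9.6-fold lower number from compound 2 to compound 3 (0.98 log units; beyond the scatter). Both gaps lie beyond the scatter, so compound 3 is the strongest inhibitor of the measured set.

Compound 4, `Cc1ccccc1C(=O)Nc1ccc(S(=O)(=O)NC2CCN(C(=O)NC(C)C)CC2)c2ccccc12`, keeps the shared core of compound 3 and changes only the terminal alkyl: isopropyl in place of methyl on an amide-type nitrogen.

Within the data shown here, no measured step alters a substituent on an amide-type nitrogen. Among the measured compounds shown here, the one step that changes alkyl size at all is on a carbonyl carbon, a 2.7-fold higher number from compound 1 to compound 2 (0.43 log units; beyond the scatter), where the smaller group gave the higher number. That is only a loose guide, and the other two steps concern the swap of alkyl for methylamino, not alkyl size. The step is therefore expected to be small: compound 4 is estimated at 0.8 nM, within 0.3 nM to 2.5 nM, corresponding to an expected 1.1-fold higher number from compound 3 to compound 4 (0.06 log units; within the scatter), a change not beyond the scatter.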

Compound 4, inhibition constant: 77.7 nM
Estimate against measurement, compound 4: 97-fold (1.99 log units) below, and the stated range ends below it.
By their numbers in this assay, from the lowest: compound 3; then compound 1; then compound 2; then compound 4.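

Isopropyl in place of methyl on an amide-type nitrogen in this assay gives a 110-fold higher number from compound 3 to compound 4 (2.05 log units; beyond the scatter), so the alkyl on this nitrogen is a sensitive point in the series and not a free choice. The advantage of methylamino over the plain alkyl groups on the carbonyl carbon, seen as a 9.6-fold lower number from compound 2 to compound 3 (0.98 log units; beyond the scatter) and a 3.6-fold lower number from compound 1 to compound 3 (0.55 log units; beyond the scatter), does not carry over to isopropylamino, which reverses the direction with a 12-fold higher number from compound 2 to compound 4 (1.06 log units; beyond the scatter) and a 31-fold higher number from compound 1 to compound 4 (1.49 log units; beyond the scatter). No measurement at hand accounts for the size of this step.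

The compounds shown leave open whether the rise follows the carbon count or the branching of the group on this nitrogen, a question that an ethyl or a straight propyl chain there would help to settle. Also open, as far as these compounds go, is whether the plain unsubstituted amino group, or a dimethylamino group with a second methyl on the same nitrogen, stays close to compound 3 at 0.7 nM or moves towards compound 4.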